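The source may hold more compounds than are shown below. What is called first, only, known or untested is meant among the compounds shown, and "the series" means these compounds.

All the measured compounds share one core and differ in a single group on an aromatic ring. In a functional assay on 786-0 cells (Homo sapiens) for inhibition, read by sulforhodamine B assay, with a stated time of 48 h (on this read-out higher numbers stand for weaker inhibition of growth and lower numbers for stronger inhibition of growth), compound 1 (`CC(C)(C)NCc1c(C(=O)O)nn(-c2ccccc2)c1-c1ccc(Br)cc1`) gives > 585000 nM as a limit of the assay and not a number. Compound 2 (`Cc1ccc(-c2c(CNC(C)(C)C)c(C(=O)O)nn2-c2ccccc2)cc1`) gives > 688000 nM as a limit too. Compound 3 (`COc1ccc(-c2c(CNC(C)(C)C)c(C(=O)O)nn2-c2ccccc2)cc1`) gives > 659000 nM as a limit as well, so it has no exact place among the three.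

The change to compound 4 (`CC(C)(C)NCc1c(C(=O)O)nn(-c2ccccc2)c1-c1ccc([N+](=O)[O-])cc1`) is nitro in place of methoxy on an aromatic carbon and reads in words as nitro in place of methoxy on an aromatic carbon. The nearest evidence is a step that the two limits leave unreadable from compound 1 to compound 2 for methyl in place of bromo, a step that the two limits leave unreadable from compound 1 to compound 3 for methoxy in place of bromo, and a step that the two limits leave unreadable from compound 2 to compound 3 for methoxy in place of methyl. None of these swaps has a measurable size. With a step that the two limits leave unreadable from compound 2 to compound 3 as the closest guide, no step beyond the scatter and no particular direction is expected in this assay and another limit is the likeliest result. The expected change is an at least 1.0-fold lower number from compound 3 to compound 4 (0.01 log units; that floor lies within the scatter) by this estimate. For compound 4 the estimated value is 640000 nM with an expected range from 400000 nM to 800000 nM in this reading.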

Compound 4, concentration for 50% growth inhibition: > 634000 nM
Compound 4: only a limit was reported; the forecaster's own chance of this, stated with the estimate: 90%; the middle value does not contradict the limit.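

Compound 4 gives > 634000 nM in this assay, a limit of the assay and not a number. Going by these compounds alone, compound 1, compound 2 and compound 3 also give only limits, so no step among the four can be read. The compounds shown leave open whether bromo, methyl, methoxy and nitro differ at all in inhibition of growth.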